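Swapping the Outer Aromatic Ring for a Cyclopentyl

A few compounds are considered here, and "the series" means these few. Any claim that something is new, unique, unknown or untested is made for them only; others in the source may bear on it.

Compound 1 `O=C1OCCN1C(=O)c1ccc(Oc2ccccc2)cc1` gives 680 nM in an assay on HEK293 cells for inhibition of N-acylethanolamine-hydrolyzing acid amidase (Rattus norvegicus), read by LC-MS, with a stated time of 30 min; a lower number here means a stronger inhibitor, a higher number a weaker inhibitor. Compound 3 `Cc1ccc(Oc2ccc(C(=O)N3CCOC3=O)cc2)cc1` carries a methyl on its outer ring, and in this assay compound 3 gives 6400 nM, the highest number among the compounds with a measured value. Compound 2 `O=C1OCCN1C(=O)c1ccc(Oc2ccc(O)cc2)cc1`, with a hydroxy on that ring, reaches only a limit of the assay in this assay, namely > 20000 nM. The step of a 9.4-fold higher number from compound 1 to compound 3 (0.97 log units; beyond the scatter) goes toward a higher number, and the step of an at least 3.1-fold lower number from compound 2 to compound 3 (0.49 log units; beyond the scatter) is bounded by the limit (the limit of > 20000 nM in this assay, at which 1 of the 3 values shown sits).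

Compound 4 `O=C1OCCN1C(=O)c1ccc(OC2CCCC2)cc1` changes the outer ring itself: cyclopentyl in place of 4-methylphenyl on an oxygen on an aromatic ring. Among the measured compounds shown here, none of the measured steps removes the aromatic ring, so they bear on this change only loosely; they show that alterations on the outer ring shift this assay by modest to large amounts in either direction. Since the unsubstituted phenyl of compound 1 at 680 nM sits well below compound 3, a lower number is expected once the methylphenyl leaves, though with wide uncertainty. Compound 4 is expected to give 2000 nM in this assay, within 400 nM to 10000 nM. This amounts to an expected step of a 3.2-fold lower number from compound 3 to compound 4 (0.51 log units; beyond the scatter).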

Compound 4, half-maximal inhibitory concentration: 120 nM
For compound 4 the middle estimate is 17-fold (1.22 log units) above the measured one; the whole stated range lies above it.
By their numbers in this assay, from the lowest: compound 4; then compound 1; then compound 3. At a limit, above all of these: compound 2.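

Compound 4 shows that an aromatic ring is not needed on this oxygen for a low number in this assay: cyclopentyl in place of the unsubstituted phenyl gives a 5.7-fold lower number from compound 1 to compound 4 (0.75 log units; beyond the scatter). Against the 4-methylphenyl, the same swap gives a 53-fold lower number from compound 3 to compound 4 (1.73 log units; beyond the scatter), which leaves compound 4 with the lowest number of the four compounds, with each of its steps beyond the scatter. Against the 4-hydroxyphenyl, the swap gives an at least 160-fold lower number from compound 2 to compound 4 (2.22 log units; beyond the scatter), a step that is only a bound set by a limit of the assay: the limit of > 20000 nM in this assay, at which 1 of the 4 values shown sits.

The compounds shown leave open whether ring size matters here, which a cyclobutyl or a cyclohexyl on the same oxygen would test. They also leave open whether a ring is needed at all, which an open pentyl chain would test, and how a hydroxy or an amine on the cyclopentyl would shift the number.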